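The source may report more compounds than this note shows. Statements on the series, on what has been measured and on what is new or still open speak of the compounds shown alone.

Of the compounds shown here, three have been measured in an assay on HEK293 cells for displacement of a labelled ligand from Melanocortin receptor 4 (Homo sapiens); a higher number here means a weaker inhibitor, a lower number a stronger inhibitor. Compound 1, `CC(C)[C@H](NC(=O)CCN(C)C)c1cccc(F)c1N1CCN(C(=O)[C@@H]2CN(C(C)C)C[C@H]2c2cc(F)c(F)c(F)c2)CC1`, gives 250 nM. Compound 3, `Cc1cccc([C@@H]2CN(C(C)C)C[C@H]2C(=O)N2CCN(c3c(F)cccc3[C@@H](NC(=O)CCN(C)C)C(C)C)CC2)c1`, gives 470 nM. Between these two the only single-point step is a 1.9-fold higher number from compound 1 to compound 3 (0.27 log units; within the scatter). Compound 2, `CNCC(=O)N[C@H](c1cc(C)ccc1N1CCN(C(=O)[C@@H]2CN(C3CCOCC3)C[C@H]2c2ccc(Cl)cc2)CC1)C(C)C`, gives 2.1 nM, the lowest number of the three; compound 1 is its nearest neighbour and compound 3 its furthest, both beyond the scatter.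

Compound 4, `Cc1ccc(N2CCN(C(=O)[C@@H]3CN(C4CCOCC4)C[C@H]3c3ccc(Cl)cc3)CC2)c([C@@H](NC(=O)[C@@H](C)N)C(C)C)c1`, has the same atoms as compound 2 joined differently: 1-aminoethyl in place of (methylamino)methyl on a carbonyl carbon. Among the measured compounds shown here, no measured pair shows this change, and the one step that has been measured lies on a saturated ring carbon and stays within the scatter, so it says nothing about what happens on the carbonyl carbon. For the measured compounds named here, with no step to lean on, the expectation in this assay is a number near that of compound 2, with a step of a 1.4-fold higher number from compound 2 to compound 4 (0.15 log units; within the scatter) that is not expected to go beyond the scatter in either direction. Compound 4 is therefore expected to give about 3 nM, within a range from 1 nM to 9 nM.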

Compound 4, inhibition constant: 7.3 nM
The estimate for compound 4 lay 2.4-fold (0.39 log units) below the measured number, within the range that was stated.
By their numbers in this assay, from the lowest: compound 2; then compound 4; then compounds 1 and 3 (each within the scatter of the next).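

In this assay, replacing (methylamino)methyl with 1-aminoethyl on the carbonyl carbon gives a 3.5-fold higher number from compound 2 to compound 4 (0.54 log units; beyond the scatter). Among the compounds shown here, this is the first step measured at this place, and it shows that the number responds to how the same atoms are joined there, whereas the only earlier step, on a saturated ring carbon, stayed within the scatter. The two groups match in heavy atoms, hydrogen-bond donors and acceptors, and differ in the defined stereocentre that 1-aminoethyl brings, but no measurement here explains the step.

The compounds shown do not separate the effect of that stereocentre from that of rejoining the atoms, since only one configuration of 1-aminoethyl appears and the opposite configuration is absent from this set. They also leave open how the number would respond to other groups on the same carbonyl carbon, such as aminomethyl, which is shorter than either group, or 1-amino-1-methylethyl, which carries a second methyl on the carbon bearing the amine.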